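Adding a Second Methoxy Group to a Strong Cytotoxic Chalcone

The source may hold more compounds than are shown below. What is called first, only, known or untested is meant among the compounds shown, and "the series" means these compounds.

Measured so far:
- compound 1, `COc1ccc(-c2cc(/C=C/C(=O)c3ccc(N)cc3)[nH]n2)cc1`, -93%
- compound 2, `COc1cc(-c2cc(/C=C/C(=O)c3ccc(Cl)c(Cl)c3)[nH]n2)cc(OC)c1OC`, 14%
- compound 3, `COc1ccc(C(=O)/C=C/c2cc(-c3cc(OC)c(OC)c(OC)c3)n[nH]2)cc1`, -48%

In a functional assay on UACC-62 cells (Homo sapiens) for cytotoxicity, read by sulforhodamine B assay, with a stated time of 48 h, tested at 100 uM (a lower number here means a stronger effect, a higher number a weaker effect of the compound at the concentration tested), compound 1 gives -93%, the lowest of the three numbers and therefore the strongest effect; compound 3 stands nearer to it and compound 2 furthest away. Among the measured compounds shown here, the one step among measured compounds that differ in a single place is a number 62 percentage points lower from compound 2 to compound 3 (beyond the scatter), where a 4-methoxyphenyl replaces a 3,4-dichlorophenyl on the carbonyl carbon. Compound 4, `COc1ccc(-c2cc(/C=C/C(=O)c3ccc(N)cc3)[nH]n2)cc1OC`, is not yet measured. It differs from compound 1 by methoxy in place of hydrogen on an aromatic carbon. This change sits on the other aryl ring, not on the carbonyl side, so the measured step does not bear on it directly; compounds 2 and 3, which carry three methoxy groups on that ring, are both weaker than compound 1, but they also differ at the carbonyl side. Compound 4 is therefore expected to stay strong, with a step of a number 18 percentage points higher from compound 1 to compound 4 (beyond the scatter), somewhat weaker but within a broad range, estimated at -75% between -100% and -30%.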

Compound 4, a percentage reported as activity, at one concentration (the size of the read-out at that concentration, not a potency): -86%
Compound 4: middle estimate off by 11 percentage points, on the high side; the measured number falls inside the stated range.
By their numbers in this assay, from the lowest: compounds 1 and 4 (each within the scatter of the next); then compound 3; then compound 2.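

In this assay, placing methoxy in place of hydrogen on the aromatic carbon ortho to a methoxy group gives a number 7 percentage points higher from compound 1 to compound 4 (within the scatter), so this carbon accepts the added group without a readable loss of effect. This is the first single change shown on the methoxy-bearing aryl ring, since the only earlier step concerned the group on the carbonyl carbon. No supporting evidence is available to explain this result.

Still open, going by these compounds, is whether another group at this carbon, such as ethoxy, an amine or a carboxylic acid, would leave the effect equally intact. Also open, on these data alone, is what a third methoxy group on this ring would do while the rest of compound 4 stays the same.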